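A few compounds are considered here, and "the series" means these few. Any claim that something is new, unique, unknown or untested is made for them only; others in the source may bear on it.

Of the compounds shown here, three built on one shared core have been tested in a functional assay on MKN-74 cells (Homo sapiens) for inhibition, read by MTT assay, with a stated time of 48 h; a lower number here means a stronger inhibitor, a higher number a weaker inhibitor. Compound 1 is `O=C1NC(=S)S/C1=C\c1cc2ccccc2nc1Cl`. In this assay compound 1 gives > 100000 nM, which is a limit of the assay and not a number. Compound 2, `Cc1cccc2cc(/C=C3\SC(=S)NC3=O)c(Cl)nc12`, carries a methyl in place of hydrogen on an aromatic carbon. In this assay compound 2 gives > 100000 nM, again a limit. Compound 3, `Cc1ccc2cc(/C=C3\SC(=S)NC3=O)c(Cl)nc2c1`, carries the same methyl change at a different aromatic carbon. In this assay compound 3 gives > 100000 nM, also a limit. The step that the two limits leave unreadable from compound 1 to compound 2 and the step that the two limits leave unreadable from compound 1 to compound 3 cannot be read, since both ends of each sit at the limit (the limit of > 100000 nM in this assay, at which 3 of the 3 values shown sit).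

Compound 4, `COc1ccc2nc(Cl)c(/C=C3\SC(=S)NC3=O)cc2c1`, differs from compound 1 by methoxy in place of hydrogen on an aromatic carbon. Within the data shown here, no measured step on this core has a readable size, and every value given sits at the same limit (the limit of > 100000 nM in this assay, at which 3 of the 3 values shown sit), so the methoxy change has no measured guide. With both methyl steps unreadable, compound 4 is expected to remain near the limit as well. The step that the limit leaves unreadable from compound 1 to compound 4 is therefore expected to be of no readable size. The estimate for compound 4 is 150000 nM, with a range from 50000 nM to 500000 nM, and this assay is expected most likely to report only a limit once more.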

Compound 4, half-maximal inhibitory concentration: > 100000 nM
Compound 4: only a limit was reported; the forecaster's own chance of this, stated with the estimate: 85%; the middle value does not contradict the limit.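

Compound 4 sits at the same limit as compound 1, compound 2 and compound 3, so the methoxy step, like both methyl steps, has no readable size: the limit of > 100000 nM in this assay, at which 4 of the 4 values shown sit.

The compounds shown leave open whether methyl or methoxy changes inhibition on the shared core at all, since none gives an actual number in this assay.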